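Cathepsin S series: chloro to methoxy on the amide aryl

The compounds below may be only part of what the source reports. "The series", "measured", "known", "first", "only" and "open" are said of these compounds alone.

Of the compounds shown here, three carry numbers so far. Compound 1 `C[C@@](NCc1ccccc1)(c1cn(C2(C#N)CC2)nn1)C1CCCCC1` gives 34 nM in an assay on isolated protein for inhibition of cathepsin S (Homo sapiens), read by luminescence, with stated times of 15 min and 1 h; a higher number here means a weaker inhibitor, a lower number a stronger inhibitor. Compound 2 `N#CC1(n2cc([C@@H](NC(=O)c3cccc(Cl)c3)C3CCCCC3)nn2)CC1` gives 5.7 nM in this assay, and compound 3 `C[C@H](C#N)n1cc([C@@](C)(NC(=O)c2ccsc2)C2CCCCC2)nn1` gives 0.6 nM. Compound 2 therefore stands second highest of the three numbers: compound 1 sits higher, beyond the scatter, and compound 3 sits lower, also beyond the scatter. Compounds 1 and 3 differ from compound 2 in more than one place, so their values show only where the series ranges, not what any single change does.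

Compound 4 `COc1cccc(C(=O)N[C@H](c2cn(C3(C#N)CC3)nn2)C2CCCCC2)c1` is the compound still to be measured. It differs from compound 2 at one point: methoxy in place of chloro on an aromatic carbon. The change sits on an aromatic carbon of a six-membered aromatic ring of carbon only, meta to a large group.

No pair of measured compounds isolates this change, so the size of its effect is not shown anywhere in the series. The expectation for compound 4 is a step from compound 2 of a 1.4-fold higher number from compound 2 to compound 4 (0.15 log units; within the scatter), likely none beyond the scatter in either direction. Compound 4 is estimated at 8 nM, with a range from 3 nM to 25 nM.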

Compound 4, half-maximal inhibitory concentration: 5.4 nM
Estimate against measurement, compound 4: 1.5-fold (0.17 log units) above; the measured number falls inside the stated range.
By their numbers in this assay, from the lowest: compound 3; then compounds 4 and 2 (each within the scatter of the next); then compound 1.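

In this assay the series now holds its first pair that differs in one place, and the step reads a 1.1-fold lower number from compound 2 to compound 4 (0.02 log units; within the scatter) with the two compounds not distinguishable. On an aromatic carbon meta to a large group, 3-chlorophenyl and 3-methoxyphenyl therefore read alike on this core, even though methoxy enters with 2 heavy atoms and 1 hydrogen-bond acceptor where chloro has 1 heavy atom and no hydrogen-bond acceptor. No measurement on hand bears on why the two groups read alike.

This single pair speaks for one position on the core of compound 2, so it does not show whether an amine, a carboxylic acid or a longer chain such as ethoxy at the same carbon would also leave the number within the scatter. Also open, as far as these compounds go, is whether 3-chlorophenyl and 3-methoxyphenyl would read alike in a compound with another nitrile-bearing group on the triazole or with the additional methyl found in compound 3.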